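Replacing an allyl with phenyl on the aryl ring

This account rests on a few compounds, and the source may have more. Where it says the series, first, only, none or still open, it means among the compounds named here.

Compound 1 `C=Cc1ccc([C@H]2CCN(C)C[C@H]2C(=O)OC)cc1` gives 131 nM in an assay on a subcellular fraction from brain for inhibition of sodium-dependent dopamine transporter (Rattus norvegicus); on this read-out lower numbers stand for stronger inhibition and higher numbers for weaker inhibition. Compound 2 `C=CCc1ccc([C@H]2CCN(C)C[C@H]2C(=O)OC)cc1` gives 964 nM in this assay, the higher of the two numbers, and the step of a 7.4-fold higher number from compound 1 to compound 2 (0.87 log units; beyond the scatter) lies beyond the scatter. Compound 3 `COC(=O)[C@@H]1CN(C)CC[C@@H]1c1ccc(-c2ccccc2)cc1` differs from compound 2 by phenyl in place of allyl on an aromatic carbon, set on an aromatic carbon para to a large group. Within the data shown here, only that one step bears on the change, and it points to a weaker number as the group grows, yet a phenyl is unlike an allyl, so no step beyond the scatter is expected, a 1.0-fold higher number from compound 2 to compound 3 (0.02 log units; within the scatter). Compound 3 is estimated at 1000 nM, in the range 250 nM to 4000 nM.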

Compound 3, inhibition constant: 173 nM
Estimate against measurement, compound 3: 5.8-fold (0.76 log units) above; measured number below the stated range.
By their numbers in this assay, from the lowest: compounds 1 and 3 (each within the scatter of the next); then compound 2.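

At this position on the aromatic ring, the number does not simply worsen as the group grows: phenyl, with more heavy atoms than allyl, brings the number down (a 5.6-fold lower number from compound 2 to compound 3 (0.75 log units; beyond the scatter)). Phenyl and vinyl cannot be told apart (a 1.3-fold higher number from compound 1 to compound 3 (0.12 log units; within the scatter)), so compound 2 is the one that stands out among these three, against any trend with size. Nothing measured here explains this difference. On these data alone, it remains open whether an ethyl or propyl chain, or a benzyl group, would track compound 2 or compounds 1 and 3.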